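A few compounds are considered here, and "the series" means these few. Any claim that something is new, unique, unknown or untested is made for them only; others in the source may bear on it.

Compound 1, `CCn1c(/C=C2/C(=O)Nc3ccccc32)nc2ccccc21`, is the parent of this small series, and in a functional assay on PC-3 cells (Homo sapiens) for cytotoxicity, read by MTT assay, with a stated time of 48 h (on this read-out lower numbers stand for stronger inhibition and higher numbers for weaker inhibition), compound 1 gives 38000 nM. Compound 2, `CCn1c(/C=C2/C(=O)Nc3ccc(Br)cc32)nc2ccccc21`, carries bromo in place of hydrogen on an aromatic carbon, and in this assay compound 2 gives 42700 nM; the change reads a 1.1-fold higher number from compound 1 to compound 2 (0.05 log units; within the scatter). Compound 3, `Cn1c(/C=C2/C(=O)Nc3ccc(Cl)cc32)nc2ccccc21`, is the analogue with chloro on the aromatic carbon and with methyl rather than ethyl on the nitrogen. In this assay compound 3 gives > 50000 nM, which is a limit of the assay and not a number, the same limit described as the limit of > 50000 nM in this assay, at which 1 of the 3 values shown sits. Compound 3 therefore stands at the weak end of what this assay can report, while compound 1 and compound 2 sit at measurable values within the scatter of each other.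

Compound 4, `CCn1c(/C=C2/C(=O)Nc3ccc(Cl)cc32)nc2ccccc21`, differs from compound 3 by methyl in place of hydrogen on a saturated chain carbon bound to an aromatic nitrogen. Going by the values given here, no measured step concerns this change, since compound 1 and compound 2 both carry ethyl; the only measured step, a 1.1-fold higher number from compound 1 to compound 2 (0.05 log units; within the scatter), concerns the halogen and lies within the scatter. Compound 4 is therefore expected to land near the values of compound 1 and compound 2, with a fair chance of reaching only a limit. Compound 4 is estimated at 45000 nM, with a range from 25000 nM to 90000 nM. The expected step is an at least 1.1-fold lower number from compound 3 to compound 4 (0.04 log units; that floor lies within the scatter).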

Compound 4, half-maximal inhibitory concentration: > 50000 nM
Compound 4 was reported as a limit (the forecaster's own chance of this, stated with the estimate: 40%); middle value at least 1.1-fold (0.04 log units) from the limit.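

The change from methyl to ethyl, on a saturated chain carbon bound to an aromatic nitrogen, does not bring the chloro analogue into the measurable range: compound 4, like compound 3, stands at a limit of the assay, and the step between them cannot be read. Against the other two compounds, the readable steps are an at least 1.1-fold higher number from compound 2 to compound 4 (0.06 log units; that floor lies within the scatter) for chloro in place of bromo and an at least 1.3-fold higher number from compound 1 to compound 4 (0.11 log units; that floor lies within the scatter) for chloro in place of hydrogen, so neither floor shows a change beyond the scatter. In this assay, both chloro compounds therefore end at the same limit: the limit of > 50000 nM in this assay, at which 2 of the 4 values shown sit.

Going by these compounds, how far compound 3 and compound 4 lie past that limit stays open, and so does any effect of this change on the chloro analogue. Also open, on these data alone, is whether a longer chain, such as propyl, or a chain ending in an amine would give a measurable value at this position.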